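Replacing the hydroxycarbamoyl end of compound 3 with carboxymethyl

This account rests on a few compounds, and the source may have more. Where it says the series, first, only, none or still open, it means among the compounds named here.

In a functional assay on HCT-116 cells (Homo sapiens) for antiproliferative activity, read by MTT assay, with a stated time of 72 h (on this read-out lower numbers stand for stronger inhibition and higher numbers for weaker inhibition), compound 1 `O=C(O)CCCCCOc1ccc2cc1COC/C=C/COCc1cccc(c1)-c1ccnc(n1)N2` gives 41000 nM, compound 2 `O=C(O)c1cccc(NCCOc2ccc3cc2COC/C=C/COCc2cccc(c2)-c2ccnc(n2)N3)c1` gives 59200 nM and compound 3 `O=C(CCCCCOc1ccc2cc1COC/C=C/COCc1cccc(c1)-c1ccnc(n1)N2)NO` gives 2560 nM, the lowest of the three numbers. Compound 4 `O=C(O)CCCCCCOc1ccc2cc1COC/C=C/COCc1cccc(c1)-c1ccnc(n1)N2` has carboxymethyl in place of hydroxycarbamoyl on a saturated chain carbon, five bonds along the chain from an oxygen on an aromatic ring. Among the compounds with values here, the closest precedent is the large step of a 16-fold lower number from compound 1 to compound 3 (1.20 log units; beyond the scatter), where hydroxyamino replaces hydroxy on a carbonyl carbon. The step of a 23-fold lower number from compound 2 to compound 3 (1.36 log units; beyond the scatter) is also large, whereas a 1.4-fold higher number from compound 1 to compound 2 (0.16 log units; within the scatter) stays within the scatter. Within the data shown here, the expected change is therefore a large rise, of about the size of the first step in the opposite direction, and the step is estimated to be a 16-fold higher number from compound 3 to compound 4 (1.19 log units; beyond the scatter). Compound 4 is estimated at 40000 nM, with an expected range of 15000 nM to 100000 nM.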

Compound 4, half-maximal inhibitory concentration: 6060 nM
For compound 4 the middle estimate is 6.6-fold (0.82 log units) above the measured one, outside the stated range (below it).
By their numbers in this assay, from the lowest: compound 3; then compound 4; then compounds 1 and 2 (each within the scatter of the next).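

Within the data shown here, at this chain end, hydroxycarbamoyl is not the only group that keeps the number low: changing it to carboxymethyl brings only a modest rise (a 2.4-fold higher number from compound 3 to compound 4 (0.37 log units; beyond the scatter)). Carboxymethyl in place of carboxy gives a modest fall (a 6.8-fold lower number from compound 1 to compound 4 (0.83 log units; beyond the scatter)), and 4-carboxybutyl in place of (3-carboxyphenyl)amino gives another (a 9.8-fold lower number from compound 2 to compound 4 (0.99 log units; beyond the scatter)), so the carboxylic acids differ clearly with their chain, though compound 3 remains the lowest. Nothing available accounts for these differences.

The compounds shown leave open whether a longer chain ending in a carboxylic acid would lower the number further. They also leave open how hydroxycarbamoyl or an amine would behave at the end of that longer chain.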